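This account rests on a few compounds, and the source may have more. Where it says the series, first, only, none or still open, it means among the compounds named here.

Of the compounds shown here, two sharing one core have been measured in a functional assay on HMEC-1 cells (Homo sapiens) for antiproliferative activity, read by cell counting, with a stated time of 4 days; a lower number here means a stronger inhibitor, a higher number a weaker inhibitor. Compound 1 `CC(=O)c1ccc(Oc2ccccc2NC(C)=C2C(=O)CC(c3ccccc3)CC2=O)cc1` gives 180 nM, and compound 2 `COc1ccc(Oc2ccccc2NC(C)=C2C(=O)CC(c3ccccc3)CC2=O)cc1` gives 83 nM, the lower of the two numbers. The next compound, compound 3 `CC(Nc1ccccc1Oc1ccccc1)=C1C(=O)CC(c2ccccc2)CC1=O`, removes the substituent altogether: hydrogen in place of methoxy on an aromatic carbon. Hydrogen stands in place of methoxy on an aromatic carbon, para to a large group, so 4-methoxyphenoxy becomes phenoxy. Among the compounds with values here, only one measured step bears on this change, and it concerns the same carbon: a 2.2-fold lower number from compound 1 to compound 2 (0.34 log units; beyond the scatter), a modest shift with methoxy in place of acetyl. That step shows that the number moves when the substituent here is exchanged. However, no measured compound carries hydrogen at this carbon, so the direction remains uncertain. Taking the step to compound 2 as the guide to size, the expected change is a 1.6-fold higher number from compound 2 to compound 3 (0.19 log units; within the scatter), a small rise no larger than the measured step. For compound 3 the estimate is 130 nM, with an expected range of 55 nM to 300 nM.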

Compound 3, half-maximal inhibitory concentration: 160 nM
Beside the measured number, compound 3's estimate is 1.2-fold (0.09 log units) below it; the measured number falls inside the stated range.
By their numbers in this assay, from the lowest: compounds 2, 3 and 1 (each within the scatter of the next, the first and the last beyond it).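

Hydrogen in place of methoxy on this aromatic carbon gives a 1.9-fold higher number from compound 2 to compound 3 (0.29 log units; within the scatter) and hydrogen in place of acetyl gives a 1.1-fold lower number from compound 1 to compound 3 (0.05 log units; within the scatter), so in this assay compound 3, which carries no substituent here, cannot be told apart from either substituted compound. The step from methoxy to acetyl had looked like a real effect of the group at this carbon, yet neither group is now shown to differ from hydrogen on its own; only the step between the two, a 2.2-fold lower number from compound 1 to compound 2 (0.34 log units; beyond the scatter), lies beyond the scatter. A substituent at this carbon is therefore not shown to be needed for the activity of the shared core in this assay.

The compounds shown leave open whether a different group on this carbon, such as a hydroxyl, an amine or a carboxylic acid, would separate from compound 3 by more than the scatter. They also leave open whether methoxy and acetyl would stay apart on another carbon of the phenoxy group. Nothing available here explains why methoxy and acetyl differ at this carbon.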